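The source may report more compounds than this note shows. Statements on the series, on what has been measured and on what is new or still open speak of the compounds shown alone.

Of the compounds shown here, three sharing one core have been tested in a functional assay on HeLa cells (Homo sapiens) for antiproliferative activity, read by MTT assay, with a stated time of 48 h; a higher number here means a weaker inhibitor, a lower number a stronger inhibitor. Compound 1 `Clc1ccc(-c2nn(-c3ccccc3)cc2-c2nc3cc(Cl)ccc3[nH]2)cc1` gives 1630 nM, compound 2 `Cc1ccc2[nH]c(-c3cn(-c4ccccc4)nc3-c3ccc(Cl)cc3)nc2c1` gives 5360 nM and compound 3 `O=C(OCc1ccccc1)c1ccc2[nH]c(-c3cn(-c4ccccc4)nc3-c3ccc(Cl)cc3)nc2c1` gives 8130 nM. Compound 2 therefore lies within the scatter of compound 3, as the data show a 1.5-fold higher number from compound 2 to compound 3 (0.18 log units; within the scatter), but clearly apart from compound 1, with a 3.3-fold higher number from compound 1 to compound 2 (0.52 log units; beyond the scatter).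

Compound 4 `COc1ccc(-c2nn(-c3ccccc3)cc2-c2nc3cc(C)ccc3[nH]2)cc1` is still unmeasured. Its difference from compound 2 is methoxy in place of chloro on an aromatic carbon, so that 4-chlorophenyl becomes 4-methoxyphenyl. For the measured compounds named here, no measured step covers this change, since all three swap a group at another place in the molecule. They offer only a rough sense of how far one swap can move the number in this small set, and the largest is a 5.0-fold higher number from compound 1 to compound 3 (0.70 log units; beyond the scatter), which is modest. Nothing in the data gives a direction, so no step beyond the scatter is expected, and the expected step is a 1.1-fold lower number from compound 2 to compound 4 (0.03 log units; within the scatter). For compound 4 the estimated value is 5000 nM, with an expected range from 2000 nM to 13000 nM.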

Compound 4, half-maximal inhibitory concentration: 3290 nM
Compound 4: middle estimate off by 1.5-fold (0.18 log units), on the high side, within the range that was stated.
By their numbers in this assay, from the lowest: compound 1; then compounds 4, 2 and 3 (each within the scatter of the next, the first and the last beyond it).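

For the compounds shown here, this is the first view of the 4-chlorophenyl group on the shared core, as every earlier step swapped a group elsewhere in the molecule. In this assay, changing 4-chlorophenyl to 4-methoxyphenyl gives a 1.6-fold lower number from compound 2 to compound 4 (0.21 log units; within the scatter) and so, for this pair, the swap of chloro for methoxy at this position cannot be told apart from repeat-measurement noise. No measurement is available that would explain this result.

Among the compounds shown, methoxy is the only replacement for chloro here, so it remains open whether an amine, a carboxylic acid or a longer chain would move the number beyond the scatter. Also open, going by these compounds, is whether methoxy would read the same with chloro rather than methyl elsewhere on the core, as in compound 1.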